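From Morpholine to Piperidine on the Thiocarbonyl Carbon

The source may hold more compounds than are shown below. What is called first, only, known or untested is meant among the compounds shown, and "the series" means these compounds.

Three compounds have been measured in a functional assay on LM7 cells (Homo sapiens) for antiproliferative activity, read by MTT assay, with a stated time of 72 h; a higher number here means a weaker inhibitor, a lower number a stronger inhibitor:

Compound 1 `CN1CCN(C(=S)SCc2coc3ccccc3c2=O)CC1` gives 17600 nM.
Compound 2 `O=c1c(CSC(=S)N2CCCCC2)coc2cc(Cl)ccc12` gives 850 nM.
Compound 3 `O=c1c(CSC(=S)N2CCOCC2)coc2ccccc12` gives 12000 nM.

Among these three numbers, compound 3 holds the second highest. Going by the values given here, its nearest neighbour is compound 1, and the only step that changes the ring on the thiocarbonyl carbon is a 1.5-fold lower number from compound 1 to compound 3 (0.17 log units; within the scatter), so that change left the number where it was. Compound 2 sits far lower, but it differs from compound 3 in two places, so its value alone cannot be credited to the ring.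

Compound 4 `O=c1c(CSC(=S)N2CCCCC2)coc2ccccc12` is the next case: piperidin-1-yl in place of morpholin-4-yl on a thiocarbonyl carbon. Among the compounds with values here, the one comparable step, from compound 1 to compound 3, stayed within the scatter, which argues for little movement. Yet compound 2, which also carries piperidin-1-yl, gives 850 nM, a far lower number, hinting that part of that gap may come from the ring. The expected step is therefore modest, downward, as a 3.4-fold lower number from compound 3 to compound 4 (0.54 log units; beyond the scatter). Compound 4 is expected to give about 3500 nM, within a range from 1000 nM to 10000 nM.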

Compound 4, half-maximal inhibitory concentration: 4600 nM
Estimate against measurement, compound 4: 1.3-fold (0.12 log units) below, within the range that was stated.
By their numbers in this assay, from the lowest: compound 2; then compound 4; then compounds 3 and 1 (each within the scatter of the next).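

In this assay the ring on the thiocarbonyl carbon now proves able to move the number: piperidin-1-yl in place of morpholin-4-yl gives a 2.6-fold lower number from compound 3 to compound 4 (0.42 log units; beyond the scatter) and piperidin-1-yl in place of 4-methylpiperazin-1-yl gives a 3.8-fold lower number from compound 1 to compound 4 (0.58 log units; beyond the scatter), whereas the earlier swap between the other two rings stayed within the scatter. Compound 4 also separates the two changes that compound 2 carried, since hydrogen in place of chloro on an aromatic carbon gives a 5.4-fold higher number from compound 2 to compound 4 (0.73 log units; beyond the scatter), so the ring and the chloro each have a step of their own. No measurement here explains either step.

As far as these compounds go, whether pyrrolidin-1-yl or an open chain such as diethylamino on the thiocarbonyl carbon would give a lower or higher number remains open. So does whether bromo or methoxy on that aromatic carbon would match chloro.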